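Aminothiazole styryl ketones: dichlorophenyl to phenyl on the nitrogen

This account rests on a few compounds, and the source may have more. Where it says the series, first, only, none or still open, it means among the compounds named here.

Measured compounds:
compound 1, `COc1cccc(/C=C/C(=O)c2sc(Nc3ccccc3)nc2C)c1`: > 25000 nM in a functional assay on NCI-H460 cells (Homo sapiens) for cytotoxicity, read by MTT assay; on this read-out higher numbers stand for weaker inhibition and lower numbers for stronger inhibition
compound 2, `Cc1nc(Nc2ccc(Cl)c(Cl)c2)sc1C(=O)/C=C/c1ccccc1`: 22700 nM in this assay

Compound 2 holds the only number shown in this assay; the other result is a limit. For compound 1 the result is a limit of the assay, > 25000 nM; (the limit of > 25000 nM in this assay, at which 1 of the 2 values shown sits). Both measured compounds therefore sit at the weak end of the read-out.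

Compound 3, `Cc1nc(Nc2ccccc2)sc1C(=O)/C=C/c1ccccc1`, differs from compound 2 by phenyl in place of 3,4-dichlorophenyl on a nitrogen on an aromatic ring. Among the measured compounds shown here, no step between measured compounds is available for this change. Compound 1 also carries phenyl on that nitrogen and gives only a limit. On that basis the step from compound 2 to compound 3 is expected to go, if beyond the scatter at all, toward weaker inhibition, a 1.3-fold higher number from compound 2 to compound 3 (0.12 log units; within the scatter). Compound 3 is estimated at 30000 nM, with a range from 12000 nM to 80000 nM, and a real chance that only a limit is reported.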

Compound 3, half-maximal inhibitory concentration: > 25000 nM
Compound 3: no number, only a limit; the forecaster's own chance of this, stated with the estimate: 55%; the middle value does not contradict the limit.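

In this assay compound 3 gives > 25000 nM, which is a limit of the assay and not a number. Phenyl in place of 3,4-dichlorophenyl on a nitrogen on an aromatic ring gives an at least 1.1-fold higher number from compound 2 to compound 3 (0.04 log units; that floor lies within the scatter), so this position now has a readable floor for the change, but that floor does not establish a real loss. The step between compound 1 and compound 3 cannot be read, and the shown results cluster at the weak end of the read-out: the limit of > 25000 nM in this assay, at which 2 of the 3 values shown sit.

On these data alone, the true size of the step from 3,4-dichlorophenyl to phenyl stays open, as the limit hides how far compound 3 lies from compound 2. Also open, as far as these compounds go, is how this assay responds on this nitrogen to a group such as a pyridine ring or a benzoic acid in place of the phenyl, or to a dimethylamino group carried on that phenyl.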